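The compounds below may be only part of what the source reports. "The series", "measured", "known", "first", "only" and "open" are said of these compounds alone.

Measured so far in an ADME assay on HepG2 cells (Homo sapiens) for cytotoxicity, read by luminescence, CellTiter-Glo and ATP content, with a stated time of 72 h; a lower number here means that less compound is needed, a higher number that more compound is needed for the effect: compound 1 `COc1ccc(Oc2ccc3c(NCCCNCc4cc(F)ccc4OC)ccnc3c2)cc1` gives 7000 nM; compound 2 `COc1ccc(F)cc1CNCCCNc1ccnc2cc(Cc3cc(C)cc(C)c3)ccc12` gives 940 nM; compound 3 `COc1ccc(F)cc1CNCCCNc1ccnc2cc(Cc3ccc(C#N)cc3)ccc12` gives 6050 nM.

Compound 3 stands second highest of the three numbers, within the scatter of compound 1 and well apart from compound 2, as the steps of a 1.2-fold lower number from compound 1 to compound 3 (0.06 log units; within the scatter) and a 6.4-fold higher number from compound 2 to compound 3 (0.81 log units; beyond the scatter) show. Compound 4 `COc1ccc(F)cc1CNCCCNc1ccnc2cc(Oc3ccc(F)cc3)ccc12` is not yet measured. It differs from compound 3 at one place: 4-fluorophenoxy in place of 4-cyanobenzyl on an aromatic carbon. The step of a 1.2-fold lower number from compound 1 to compound 3 (0.06 log units; within the scatter) bears directly on it, since it trades a phenoxy group for a benzyl group at the same aromatic carbon and stays within the scatter. The swap of aryl substituents in a 6.4-fold higher number from compound 2 to compound 3 (0.81 log units; beyond the scatter) was modest but does not involve a phenoxy. For compound 4 the expectation is therefore a 1.1-fold higher number from compound 3 to compound 4 (0.03 log units; within the scatter), no step beyond the scatter, and an estimated value of 6500 nM in this assay, with a range of 2500 nM to 16000 nM.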

Compound 4, half-maximal effective concentration: 6600 nM
Estimate against measurement, compound 4: 1.0-fold (0.01 log units) below, and the stated range covers the measured number.
By their numbers in this assay, from the lowest: compound 2; then compounds 3, 4 and 1 (each within the scatter of the next).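

In this assay, 4-fluorophenoxy on this aromatic carbon adds a third group to the cluster of 4-cyanobenzyl (step: a 1.1-fold higher number from compound 3 to compound 4 (0.04 log units; within the scatter)) and the 4-methoxyphenoxy of compound 1 (step: a 1.1-fold lower number from compound 1 to compound 4 (0.03 log units; within the scatter)), so swapping fluoro for methoxy on the phenoxy and exchanging phenoxy for benzyl both leave the number within the scatter. Among the compounds shown here, the 3,5-dimethylbenzyl of compound 2 remains the only group apart (step: a 7.0-fold higher number from compound 2 to compound 4 (0.85 log units; beyond the scatter)). Nothing available accounts for this separation. Open, on these data alone, is how a carboxylic acid, a morpholine or a longer chain on this carbon would read, and whether other dimethyl-substituted groups follow compound 2.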